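This account rests on a few compounds, and the source may have more. Where it says the series, first, only, none or still open, it means among the compounds named here.

In a functional assay on L1210 cells (Mus musculus) for antiproliferative activity, with a stated time of 48 h (on this read-out higher numbers stand for weaker inhibition and lower numbers for stronger inhibition), compound 1 `C=C(Br)C(=O)Nc1ccc(/C=C/C(=O)c2ccccc2)cc1` gives 5000 nM, compound 2 `C=C(Br)C(=O)Nc1ccc(/C=C/C(=O)c2ccc(Cl)c(Cl)c2)cc1` gives 2100 nM, and compound 3 `C=C(Br)C(=O)Nc1ccc(/C=C/C(=O)c2ccc(Br)cc2)cc1` gives 620 nM, the lowest number of the three. Compound 4 `C=C(Br)C(=O)Nc1ccc(/C=C/C(=O)c2ccc(I)cc2)cc1` is still unmeasured. It differs from compound 3 by iodo in place of bromo on an aromatic carbon, with iodo in place of bromo on an aromatic carbon, para to a large group. Among the compounds with values here, no measured step swaps one of these halogens for the other. The nearest evidence is an 8.1-fold lower number from compound 1 to compound 3 (0.91 log units; beyond the scatter), where bromo replaces hydrogen, and a 3.4-fold lower number from compound 2 to compound 3 (0.53 log units; beyond the scatter). Both are modest, so a small further drop in this assay is expected, possibly none beyond the scatter. For compound 4 the estimated value is 450 nM, with an expected range from 180 nM to 1100 nM. The expected change is a 1.4-fold lower number from compound 3 to compound 4 (0.14 log units; within the scatter).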

Compound 4, half-maximal inhibitory concentration: 3400 nM
Compound 4: middle estimate off by 7.6-fold (0.88 log units), on the low side; measured number above the stated range.
By their numbers in this assay, from the lowest: compound 3; then compounds 2, 4 and 1 (each within the scatter of the next, the first and the last beyond it).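

At this position, para to a large group, the two halogens are not interchangeable in this assay: iodo in place of bromo gives (a 5.5-fold higher number from compound 3 to compound 4 (0.74 log units; beyond the scatter)), so the drop that came with bromo does not extend to iodo. Iodo in place of hydrogen gives only (a 1.5-fold lower number from compound 1 to compound 4 (0.17 log units; within the scatter)), and the 4-iodophenyl and 3,4-dichlorophenyl compounds cannot be told apart (a 1.6-fold higher number from compound 2 to compound 4 (0.21 log units; within the scatter)). Nothing measured here accounts for this reversal. The compounds shown leave open how fluoro, a methoxy group or an amine would read at this place, and so whether bromo stands alone here.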